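This account rests on a few compounds, and the source may have more. Where it says the series, first, only, none or still open, it means among the compounds named here.

In an ADME assay on L1210 cells (Mus musculus) for inhibition, read by cell counting (on this read-out higher numbers stand for weaker inhibition and lower numbers for stronger inhibition), compound 1 `CSc1nc(NCCCCNc2ccnc3cc(Cl)ccc23)c(C#N)c(-c2ccccc2)n1` gives 4400 nM, and compound 3 `CSc1nc(NCCCCNc2ccnc3cc(Cl)ccc23)c(C#N)c(-c2ccc([N+](=O)[O-])cc2)n1` gives 960 nM. For the measured compounds named here, that step, a 4.6-fold lower number from compound 1 to compound 3 (0.66 log units; beyond the scatter), is the only measured change of its kind. Compound 2 `CSc1nc(-c2ccccc2)c(C#N)c(N2CCN(c3ccnc4cc(Cl)ccc34)CC2)n1` is the piperazine-linked analogue; in this assay compound 2 reaches only the limit > 250000 nM, which is a boundary of the assay rather than a number, the case described by the limit of > 250000 nM in this assay, at which 1 of the 3 values shown sits. Compound 4 `CSc1nc(-c2ccc([N+](=O)[O-])cc2)c(C#N)c(N2CCN(c3ccnc4cc(Cl)ccc34)CC2)n1` differs from compound 2 by nitro in place of hydrogen on an aromatic carbon. If the same change acted as it did in going from compound 1 to compound 3, a modest lowering would follow, but from a limit the result may still sit at or near that limit. Compound 4 is therefore expected to give about 150000 nM, within 30000 nM to 800000 nM, a step of an at least 1.6-fold lower number from compound 2 to compound 4 (0.22 log units; that floor lies within the scatter).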

Compound 4, half-maximal inhibitory concentration: 206000 nM
Compound 4: middle estimate off by 1.4-fold (0.14 log units), on the low side, within the range that was stated.
By their numbers in this assay, from the lowest: compound 3; then compound 1; then compound 4. At a limit, above all of these: compound 2.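

In this assay, phenyl to 4-nitrophenyl on the piperazine-linked core comes out as an at least 1.2-fold lower number from compound 2 to compound 4 (0.08 log units; that floor lies within the scatter), so the same change now has a reading on a second core. Even with the nitro group in place, compound 4 stands at 206000 nM, while compound 3 stands at 960 nM. Whether the change does as much on both cores cannot be read: the same change on two cores in this assay, a 4.6-fold lower number (0.66 log units; beyond the scatter) from compound 1 to compound 3 and an at least 1.2-fold lower number (0.08 log units; that floor lies within the scatter) from compound 2 to compound 4; the limit leaves it open whether they differ

The compounds shown leave open whether an amine or a carboxylic acid on the same ring carbon would act as nitro does. They also leave open how a longer chain than that of compound 3 would read.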